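Growth inhibition: methoxy to 4-bromophenoxy on compound 1

A few compounds are considered here, and "the series" means these few. Any claim that something is new, unique, unknown or untested is made for them only; others in the source may bear on it.

Measured in a functional assay on MCF7 cells (Homo sapiens) for inhibition, read by sulforhodamine B assay, with a stated time of 48 h, tested at 50 uM; on this read-out higher numbers stand for more inhibition of growth at the one concentration tested and lower numbers for less inhibition of growth:
- compound 1 `COc1ccc([C@@H]2CC(=O)c3cc(CC=C(C)C)c(OC)cc3O2)cc1`: 65%
- compound 2 `COc1ccc([C@@H]2C/C(=N/OCc3cn(-c4ccc(C(=O)c5ccccc5)cc4)nn3)c3cc(CC=C(C)C)c(OC)cc3O2)cc1`: 41%
- compound 3 `COc1ccc([C@@H]2C/C(=N/OCc3cn(-c4cccc(CO)c4)nn3)c3cc(CC=C(C)C)c(OC)cc3O2)cc1`: 42%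

Compound 1 stands highest of the three, with compound 2 and compound 3 both lower by more than the usual scatter. Those two lie within the scatter of each other.

Next in view is compound 4 `COc1cc2c(cc1CC=C(C)C)C(=O)C[C@@H](c1ccc(Oc3ccc(Br)cc3)cc1)O2`, which has 4-bromophenyl in place of methyl on an oxygen on an aromatic ring, or methoxy to 4-bromophenoxy: 4-bromophenyl in place of methyl on an oxygen on an aromatic ring. Going by the values given here, no measured pair isolates a change of this kind, so the expectation rests on little. With compound 1 at 65%, the top of the three values, a fall is considered likelier than a rise. A moderate downward step is expected in this assay, estimated as a number 15 percentage points lower from compound 1 to compound 4 (beyond the scatter). For compound 4 the estimated value is 50%, with an expected range of 28% to 72%.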

Compound 4, percent growth inhibition at one concentration: 68%
Beside the measured number, compound 4's estimate is 18 percentage points below it; the range from low to high includes it.
By their numbers in this assay, from the lowest: compounds 2 and 3 (each within the scatter of the next); then compounds 1 and 4 (each within the scatter of the next).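

In this assay, 4-bromophenyl in place of methyl on an oxygen on an aromatic ring gives a number 3 percentage points higher from compound 1 to compound 4 (within the scatter). This position of the core of compound 1 therefore accepts a much larger group carrying an added aromatic ring, with no difference in growth inhibition that this read-out can separate from the scatter. Nothing available explains why the larger group leaves the read-out unchanged.

On these data alone, it remains open whether this holds for other groups on the same oxygen, such as unsubstituted phenyl, benzyl, or a longer chain ending in an amine or a carboxylic acid. As far as these compounds go, with only one concentration tested, it is also open whether compound 1 and compound 4 would separate at lower concentrations.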